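A few compounds are considered here, and "the series" means these few. Any claim that something is new, unique, unknown or untested is made for them only; others in the source may bear on it.

Three compounds share one core and differ only in the ring carried on the amine nitrogen: compound 1 `CC(C)c1ccc(-c2nc(SCc3cn(CC(=O)NC(=O)Nc4ccccn4)nn3)nc(Nc3cccc(C(F)(F)F)c3)c2C#N)cc1`, compound 2 `CC(C)c1ccc(-c2nc(SCc3cn(CC(=O)NC(=O)Nc4ccccn4)nn3)nc(Nc3ccccc3F)c2C#N)cc1` and compound 3 `Cc1cccc(Nc2nc(SCc3cn(CC(=O)NC(=O)Nc4ccccn4)nn3)nc(-c3ccc(C(C)C)cc3)c2C#N)c1`. In a functional assay on ECa-109 cells (Homo sapiens) for inhibition, read by MTT assay, with a stated time of 72 h (a higher number here means a weaker inhibitor, a lower number a stronger inhibitor), compound 1 gives 24200 nM, compound 2 gives 15500 nM and compound 3 gives 7320 nM, so compound 1 carries the highest of the three numbers. Compound 4 `Cc1ccc(-c2nc(SCc3cn(CC(=O)NC(=O)Nc4ccccn4)nn3)nc(Nc3cccc(C(F)(F)F)c3)c2C#N)cc1` changes a different place: methyl in place of isopropyl on an aromatic carbon. Among the measured compounds shown here, none of the measured steps touches that group; a 1.6-fold lower number from compound 1 to compound 2 (0.19 log units; within the scatter), a 3.3-fold lower number from compound 1 to compound 3 (0.52 log units; beyond the scatter) and a 2.1-fold lower number from compound 2 to compound 3 (0.33 log units; beyond the scatter) all concern the other ring and were small or modest. With nothing to suggest the isopropyl matters, the expected step is a 1.2-fold higher number from compound 1 to compound 4 (0.09 log units; within the scatter), nothing beyond the scatter. Compound 4 is therefore estimated at 30000 nM, in a range from 10000 nM to 90000 nM.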

Compound 4, half-maximal inhibitory concentration: 32300 nM
Beside the measured number, compound 4's estimate is 1.1-fold (0.03 log units) below it; the measured number falls inside the stated range.
By their numbers in this assay, from the lowest: compound 3; then compounds 2, 1 and 4 (each within the scatter of the next, the first and the last beyond it).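

Among the compounds shown here, compound 4 gives the first reading on the 4-isopropylphenyl ring rather than the ring on the amine nitrogen: in this assay, changing it to 4-methylphenyl gives a 1.3-fold higher number from compound 1 to compound 4 (0.13 log units; within the scatter) and stays within the scatter. With the 3-(trifluoromethyl)phenyl group held in place, these two alkyl groups therefore cannot be told apart at this position. No measured evidence here explains this result. Still open, as far as these compounds go, is whether an amine, a carboxylic acid or a longer chain at this position would shift the number, and whether methyl and isopropyl also match when the amine nitrogen carries the 3-methylphenyl ring of compound 3.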